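The compounds below may be only part of what the source reports. "The series", "measured", "known", "first", "only" and "open" are said of these compounds alone.

Measured so far:
Compound 1, `CC/C(=C(/c1ccc(/C=C/C(=O)O)cc1)c1ccc2[nH]ncc2n1)c1ccccc1`: 33 nM
Compound 2, `CC/C(=C(/c1ccc(/C=C/C(=O)O)cc1)c1ccc2[nH]ncc2c1Cl)c1ccccc1`: 1.6 nM

In a functional assay on MCF7 cells (Homo sapiens) for cytotoxicity, read by CellTiter-Glo, with a stated time of 5 days (on this read-out lower numbers stand for stronger inhibition and higher numbers for weaker inhibition), compound 1 gives 33 nM, while compound 2 gives 1.6 nM. Compound 2 therefore holds the lower of the two numbers, set apart from compound 1 by the step of a 21-fold lower number from compound 1 to compound 2 (1.31 log units; beyond the scatter), a clear difference well beyond the usual scatter.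

The unmeasured compound 3, `CC/C(=C(/c1ccc(/C=C/C(=O)O)cc1)c1cc2cn[nH]c2cc1Cl)c1ccccc1`, differs from compound 2 by 6-chloro-1H-indazol-5-yl in place of 4-chloro-1H-indazol-5-yl on a double-bonded chain carbon bound to an aromatic carbon and a double-bonded chain carbon. The two compounds contain exactly the same atoms; only the chlorine has moved to another position on the indazole ring.

Among the measured compounds shown here, only one measured step exists, a 21-fold lower number from compound 1 to compound 2 (1.31 log units; beyond the scatter), and it changed two things at once: the ring system and the addition of chlorine. For the measured compounds named here, it does not isolate the effect of moving a chlorine from one ring position to another, so no measured pair bears directly on the change from compound 2 to compound 3. The expectation is held loosely: the number for compound 3 is expected to rise somewhat, a 5.0-fold higher number from compound 2 to compound 3 (0.70 log units; beyond the scatter), with a wide margin in both directions. Compound 3 is estimated at 8 nM in this assay, with a range from 1.5 nM to 45 nM.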

Compound 3, half-maximal inhibitory concentration: 137 nM
Compound 3: the middle estimate sits 17-fold (1.23 log units) below what was measured; the whole stated range lies below it.
By their numbers in this assay, from the lowest: compound 2; then compound 1; then compound 3.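

In this assay, the atoms stay the same and only the chlorine moves, yet 6-chloro-1H-indazol-5-yl in place of 4-chloro-1H-indazol-5-yl gives an 86-fold higher number from compound 2 to compound 3 (1.93 log units; beyond the scatter), so at this double-bonded chain carbon the chlorine's place on the ring matters, not merely its presence. The earlier step, a 21-fold lower number from compound 1 to compound 2 (1.31 log units; beyond the scatter), had changed the ring and added chlorine together, and it could have suggested that the chlorine-bearing group was enough for a lower number; compound 3 carries the same atoms as compound 2 and still goes the other way, with a 4.2-fold higher number from compound 1 to compound 3 (0.62 log units; beyond the scatter). Nothing measured here explains why the chlorine's place has so large an effect.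

On these data alone, it remains open whether fluorine or a methyl group could stand in for the chlorine of 4-chloro-1H-indazol-5-yl and keep a number as low as that of compound 2. The compounds shown also leave open what the plain 1H-indazol-5-yl group, with no chlorine at all, would give, and so how much of the step to compound 2 belongs to the chlorine and how much to the ring.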